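The source may report more compounds than this note shows. Statements on the series, on what has been measured and on what is new or still open speak of the compounds shown alone.

Measured so far in an ADME assay on microsomes from liver (Mus musculus) for metabolic stability, read by LC-MS, using NADPH, with a stated time of 10 min, tested at 0.1 uM; on this read-out lower numbers stand for slow clearance and higher numbers for fast clearance:
- compound 1 `CC1SC(c2cccc(C(=O)NCCCCc3ccccc3)c2)N(c2ccc(C3CC3)cc2)C1=O`: 3210 mL.min-1.g-1
- compound 2 `Cc1cccc(N2C(=O)CSC2c2cccc(C(=O)NCCCCc3ccccc3)c2)c1`: 2940 mL.min-1.g-1
- compound 3 `O=C(NCCCCc1ccccc1)c1cccc(C2SCC(=O)N2c2cccc(-c3c[nH]nn3)c2)c1`: 951 mL.min-1.g-1

Compound 3 stands lowest of the three, and the numbers for compound 1 and compound 2 both lie higher by amounts beyond the scatter. Next comes compound 4 `C#Cc1cccc(N2C(=O)CSC2c2cccc(C(=O)NCCCCc3ccccc3)c2)c1`, with ethynyl in place of 1H-1,2,3-triazol-4-yl on an aromatic carbon, meta to a large group: ethynyl in place of 1H-1,2,3-triazol-4-yl on an aromatic carbon.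

Among the compounds with values here, one measured step bears on this change: a 3.1-fold lower number from compound 2 to compound 3 (0.49 log units; beyond the scatter), a modest step beyond the scatter, in which the same 1H-1,2,3-triazol-4-yl replaced methyl. Compound 4 gives up that group for ethynyl, which has no ring, as methyl has none. Within the data shown here, a move back towards compound 2 at 2940 mL.min-1.g-1 is therefore expected, of similar or slightly smaller size, though no measured step covers ethynyl itself.

The expected move, towards a higher number, is a 2.6-fold higher number from compound 3 to compound 4 (0.42 log units; beyond the scatter). The estimate for compound 4 is 2500 mL.min-1.g-1, with an expected range of 1400 mL.min-1.g-1 to 4200 mL.min-1.g-1.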

Compound 4, intrinsic clearance in microsomes: 1900 mL.min-1.g-1
Estimate against measurement, compound 4: 1.3-fold (0.12 log units) above; the range from low to high includes it.
By their numbers in this assay, from the lowest: compounds 3, 4, 2 and 1 (each within the scatter of the next, the first and the last beyond it).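

In this assay ethynyl on this aromatic carbon, meta to a large group, separates from neither of the other two groups: a 2.0-fold higher number from compound 3 to compound 4 (0.30 log units; within the scatter) and a 1.5-fold lower number from compound 2 to compound 4 (0.19 log units; within the scatter) are both printed as within the scatter. Methyl and 1H-1,2,3-triazol-4-yl stay apart by a 3.1-fold lower number from compound 2 to compound 3 (0.49 log units; beyond the scatter) and this remains the only step beyond the scatter at this position, so compound 4 cannot be assigned to either side of it. No measurement given here accounts for these numbers.

On these data alone, whether a nitrile, a carboxylic acid or an amine on the same aromatic carbon would read with compound 2 or with compound 3 remains open. So does whether another five-membered aromatic ring there would read with compound 3.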